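The source may report more compounds than this note shows. Statements on the series, on what has been measured and on what is new or still open speak of the compounds shown alone.

Notes on the series in a functional assay on HT-29 cells (Homo sapiens) for inhibition, read by luminescence and CellTiter-Glo, with a stated time of 24 h; a lower number here means that less compound is needed, a higher number that more compound is needed for the effect. Compound 1 `CCCCCn1nc(C(=O)N[C@H]2COc3ccccc3N(C)C2=S)nc1Cc1ccccc1` gives 805 nM, compound 2 `CC(C)Cn1nc(C(=O)N[C@H]2COc3ccccc3N(C)C2=S)nc1Cc1ccccc1` gives 1230 nM and compound 3 `CC(C)CCn1nc(C(=O)N[C@H]2COc3ccccc3N(C)C2=S)nc1Cc1ccccc1` gives 3640 nM, the highest number of the three. Compound 4 `CN1C(=S)[C@@H](NC(=O)c2nc(Cc3ccccc3)n(CCCC(F)(F)F)n2)COc2ccccc21` is not yet measured. Its change is 2,2,2-trifluoroethyl in place of isopropyl on a saturated chain carbon, two bonds along the chain from an aromatic nitrogen, which also reads isopentyl to 4,4,4-trifluorobutyl. Among the measured compounds shown here, two measured steps bear on it: a 4.5-fold higher number from compound 1 to compound 3 (0.66 log units; beyond the scatter), where the same isopropyl enters, and a 3.0-fold higher number from compound 2 to compound 3 (0.47 log units; beyond the scatter). The remaining step, a 1.5-fold higher number from compound 1 to compound 2 (0.18 log units; within the scatter), stays within the scatter. For the measured compounds named here, no measured compound carries fluorine, and the estimate rests on the chain steps alone. Removing the isopropyl is expected to give a lower number, recovering part of the step that brought it in. The expected step is a 2.3-fold lower number from compound 3 to compound 4 (0.36 log units; beyond the scatter). For compound 4 the estimated value is 1600 nM, with an expected range of 600 nM to 4000 nM.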

Compound 4, half-maximal effective concentration: 2380 nM
Compound 4: the middle estimate sits 1.5-fold (0.17 log units) below what was measured; the range from low to high includes it.
By their numbers in this assay, from the lowest: compounds 1, 2, 4 and 3 (each within the scatter of the next, the first and the last beyond it).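

In this assay, 4,4,4-trifluorobutyl, the first fluorinated chain at this position, cannot be told apart from the branched chains: a 1.5-fold lower number from compound 3 to compound 4 (0.18 log units; within the scatter) and a 1.9-fold higher number from compound 2 to compound 4 (0.29 log units; within the scatter) both stay within the scatter. The unbranched chain of compound 1 stands apart, with a 3.0-fold higher number from compound 1 to compound 4 (0.47 log units; beyond the scatter). Nothing measured on these compounds offers an explanation for these steps. Still open, going by these compounds, is how this position responds to a chain ending in an amine or a carboxylic acid, and to a chain longer than pentyl.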